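The compounds below may be only part of what the source reports. "The series", "measured", "known", "first", "only" and "open" are said of these compounds alone.

Three compounds share one core and differ only in the halogen-bearing benzyl group that sits on a saturated chain carbon bound to an aromatic nitrogen. Compound 1 `COc1ccc(C(=O)/C=C/c2ccc(OCc3cn(Cc4ccccc4Br)nn3)cc2)cc1` gives 10000 nM in a functional assay on MIA PaCa-2 cells (Homo sapiens) for cytotoxicity, read by MTT assay, with a stated time of 48 h; on this read-out higher numbers stand for weaker inhibition and lower numbers for stronger inhibition. Compound 2 `COc1ccc(C(=O)/C=C/c2ccc(OCc3cn(Cc4cccc(Br)c4)nn3)cc2)cc1` gives 10000 nM in this assay. Compound 3 `COc1ccc(C(=O)/C=C/c2ccc(OCc3cn(Cc4ccc(Br)cc4)nn3)cc2)cc1` gives 8000 nM in this assay, the lowest of the three numbers, though its distance to the others stays within the scatter: a 1.3-fold lower number from compound 1 to compound 3 (0.10 log units; within the scatter) and a 1.3-fold lower number from compound 2 to compound 3 (0.10 log units; within the scatter), and likewise no change at the digits printed from compound 1 to compound 2 (within the scatter).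

Compound 4 `COc1ccc(C(=O)/C=C/c2ccc(OCc3cn(Cc4cccc(F)c4)nn3)cc2)cc1` is the next step from compound 3: 3-fluorophenyl in place of 4-bromophenyl on a saturated chain carbon bound to an aromatic nitrogen. Two of the measured steps bear on it, since they also swap the bromophenyl from one position to another, and both were within the scatter. Within the data shown here, no measured step swaps bromine for fluorine, so that part of the change is untested here. On this evidence the step from compound 3 to compound 4 is expected to be small, a 1.3-fold higher number from compound 3 to compound 4 (0.10 log units; within the scatter), with no clear direction. Compound 4 is therefore estimated to give 10000 nM in this assay, within a range from 4000 nM to 25000 nM.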

Compound 4, half-maximal inhibitory concentration: 15000 nM
Compound 4: middle estimate off by 1.5-fold (0.18 log units), on the low side; the measured number falls inside the stated range.
By their numbers in this assay, from the lowest: compounds 3, 1, 2 and 4 (each within the scatter of the next).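

Among these compounds, the step of a 1.5-fold higher number from compound 2 to compound 4 (0.18 log units; within the scatter) is the first direct test of fluoro in place of bromo on an aromatic carbon, and it shows that exchanging the halogen, with the 3-position name unchanged, does not move the number beyond the scatter. The two remaining steps, a 1.9-fold higher number from compound 3 to compound 4 (0.27 log units; within the scatter) and a 1.5-fold higher number from compound 1 to compound 4 (0.18 log units; within the scatter), change the halogen and its ring position together and also stay within the scatter, so in this assay these four compounds cannot be put in a reliable order. Nothing available here explains these numbers.

Going by these compounds, whether 2-fluorophenyl or 4-fluorophenyl would behave the same way remains open. So does whether an amine or a carboxylic acid on this ring, or a longer chain carrying it, would shift the number beyond the scatter.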